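The compounds below may be only part of what the source reports. "The series", "measured", "known", "first", "only" and "open" are said of these compounds alone.

Measured compounds:
Compound 1 `Cc1cc(C)c(S(=O)(=O)N[C@@H](CNC(=O)C2=NO[C@]3(CN[C@H](CNc4ncc[nH]4)C3)C2)C(=O)O)c(C)c1`: 230 nM
Compound 2 `Cc1cc(-c2ccccc2)cc(C)c1S(=O)(=O)[C@@H](CNC(=O)C1=NOC2(CCC(CNc3ncc[nH]3)CC2)C1)C(=O)O`: 670 nM
Compound 3 `Cc1cc(C)c(S(=O)(=O)[C@@H](CNC(=O)C2=NOC3(CCC(CNc4ncc[nH]4)CC3)C2)C(=O)O)c(C)c1`: 1500 nM

In a functional assay for antagonist activity at integrin alpha-5/beta-1 (Homo sapiens), read by ELISA (on this read-out higher numbers stand for weaker inhibition and lower numbers for stronger inhibition), compound 1 gives 230 nM, the lowest of the three numbers. Compound 2 gives 670 nM, and compound 3 gives 1500 nM; the gap from compound 1 to compound 2 and the wider gap from compound 1 to compound 3 both lie beyond the scatter. Among the compounds with values here, the only step between compounds that differ in one place is a 2.2-fold higher number from compound 2 to compound 3 (0.35 log units; beyond the scatter), which concerns a substituent on an aromatic carbon of the sulfonyl-bearing ring.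

Compound 4 `Cc1cc(C)c(S(=O)(=O)N[C@@H](CNC(=O)C2=NO[C@]3(C2)C[C@@H](CNc2ncc[nH]2)N(C(=O)OCc2cccnc2)C3)C(=O)O)c(C)c1` is the unmeasured compound. It differs from compound 1 in ((pyridin-3-yl)methoxy)carbonyl in place of hydrogen on an amine nitrogen in a ring. Within the data shown here, no measured pair probes a change on this ring nitrogen; the step from compound 2 to compound 3 concerns a different part of the shared core and says nothing directly about a group entering on the amine nitrogen in a ring. Among the measured compounds shown here, the expectation for compound 4 in this assay therefore rests on compound 1 alone, and with no step bearing on this position, the estimate is a number close to that of compound 1, with a wide range to allow for a change in either direction beyond the scatter; the estimated step is a 1.1-fold higher number from compound 1 to compound 4 (0.04 log units; within the scatter). For compound 4 the estimated value in this assay is 250 nM, expected to fall between 70 nM and 900 nM.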

Compound 4, half-maximal inhibitory concentration: 39 nM
For compound 4 the middle estimate is 6.4-fold (0.81 log units) above the measured one; the measured number lies below the stated range.
By their numbers in this assay, from the lowest: compound 4; then compound 1; then compound 2; then compound 3.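

In this assay, ((pyridin-3-yl)methoxy)carbonyl in place of hydrogen on the amine nitrogen in a ring gives a 5.9-fold lower number from compound 1 to compound 4 (0.77 log units; beyond the scatter). Within the data shown here, this shows that the nitrogen, which carries hydrogen in compound 1, can bear a group of 10 heavy atoms with stronger inhibition rather than a loss, something the earlier compounds could not show: their only step, a 2.2-fold higher number from compound 2 to compound 3 (0.35 log units; beyond the scatter), concerns a substituent on an aromatic carbon and leaves this nitrogen untouched. Nothing measured here accounts for the lower number.

From the compounds shown here alone, with a single group on this nitrogen, it remains open which part of ((pyridin-3-yl)methoxy)carbonyl goes with the step: the pyridin-3-yl ring, the methoxy link or the carbonyl. Going by these compounds, a benzyloxycarbonyl group, with phenyl in place of pyridin-3-yl, an acetyl group or a simple methyl on the same nitrogen would begin to separate these parts, and it also remains open whether the step would carry over to the phenyl-bearing sulfonyl ring of compound 2.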